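From phenyl to neopentyl on a shared side chain

The source may report more compounds than this note shows. Statements on the series, on what has been measured and on what is new or still open speak of the compounds shown alone.

- compound 1 `CC(C)(C)[C@@H](O)C(=O)N1OCC[C@H]1C(=O)NCc1cc(Cl)ccc1-n1cnnn1` gives 1600 nM
- compound 2 `CCCC[C@@H](O)C(=O)N1C[C@H]2C[C@H]2[C@H]1C(=O)NCc1cc(Cl)ccc1-n1cnnn1` gives 750 nM
- compound 3 `O=C(NCc1cc(Cl)ccc1-n1cnnn1)[C@@H]1CCON1C(=O)[C@H](O)c1ccccc1` gives 1500 nM

All three numbers come from a functional assay on a cell-free system (plasma, Homo sapiens), with a stated time of 3 min (a higher number here means a weaker inhibitor, a lower number a stronger inhibitor), and form a narrow set. Among them compound 3 at 1500 nM stands second highest, though its gaps to compound 1 and to compound 2 both lie within the scatter.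

Compound 4 `CC(C)(C)C[C@@H](O)C(=O)N1OCC[C@H]1C(=O)NCc1cc(Cl)ccc1-n1cnnn1` has not yet been measured. What separates it from compound 3 is neopentyl in place of phenyl on a saturated chain carbon bound to a carbonyl carbon and an oxygen on a saturated carbon and in words this is neopentyl in place of phenyl on a saturated chain carbon bound to a carbonyl carbon and an oxygen on a saturated carbon.

Among the measured compounds shown here, the only measured step at this place is a 1.1-fold lower number from compound 1 to compound 3 (0.03 log units; within the scatter) and it stays within the scatter. For the measured compounds named here, compound 2 at 750 nM differs from compound 3 in more than one place, so it offers no single-change step to draw on. Given that small step to compound 3 from compound 1 at 1600 nM no shift beyond the scatter is expected in this assay here. The expected size is a 1.2-fold lower number from compound 3 to compound 4 (0.06 log units; within the scatter) and this remains an estimate resting on one step. For compound 4 the estimated value is 1300 nM with 550 nM to 3000 nM as the expected range.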

Compound 4, half-maximal inhibitory concentration: 1100 nM
Estimate against measurement, compound 4: 1.2-fold (0.07 log units) above; measured number inside the range.
By their numbers in this assay, from the lowest: compounds 2, 4, 3 and 1 (each within the scatter of the next, the first and the last beyond it).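

In this assay, three groups have now been read at the saturated chain carbon bound to a carbonyl carbon and an oxygen on a saturated carbon, all on the same core, and the new compound adds two steps: neopentyl in place of phenyl gives (a 1.4-fold lower number from compound 3 to compound 4 (0.13 log units; within the scatter)) and neopentyl in place of tert-butyl gives (a 1.5-fold lower number from compound 1 to compound 4 (0.16 log units; within the scatter)). The earlier step (a 1.1-fold lower number from compound 1 to compound 3 (0.03 log units; within the scatter)) was a single pair, whereas these steps together show that tert-butyl, phenyl and neopentyl are not told apart here, whether or not the group carries a ring and whatever its count of heavy atoms among these three. Nothing available accounts for this lack of separation.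

On these data alone, all three groups contain carbon only, so it remains open whether an amine or a carboxylic acid at this place would give a step beyond the scatter. As far as these compounds go, it is also open whether neopentyl would behave the same way on the core of compound 2, which differs from these compounds in more than one place.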